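The source may report more compounds than this note shows. Statements on the series, on what has been measured and on what is new or still open speak of the compounds shown alone.

Measured compounds in an assay on isolated protein for inhibition of acyl-CoA:cholesterol acyltransferase (Oryctolagus cuniculus); a lower number here means a stronger inhibitor, a higher number a weaker inhibitor:
compound 1 `CCCc1ccc(NC(=O)Nc2c(C(C)C)cccc2C(C)C)cc1` gives 38 nM
compound 2 `CCCCCCCc1ccc(NC(=O)Nc2c(C(C)C)cccc2C(C)C)cc1` gives 19 nM
compound 3 `CCCCc1ccc(NC(=O)Nc2c(C(C)C)cccc2C(C)C)cc1` gives 29 nM

Compound 3 stands second highest of the three numbers; its nearest neighbour is compound 1 and its furthest is compound 2, and both gaps are within the scatter, so no order among the three can be read from them. Compound 4 `CC(C)c1cccc(C(C)C)c1NC(=O)Nc1ccc(C(C)(C)C)cc1` is not yet measured; relative to compound 3 the change is tert-butyl in place of butyl on an aromatic carbon. Going by the values given here, the steps that bear on it are the changes of chain length on the same aromatic carbon: a 1.3-fold lower number from compound 1 to compound 3 (0.12 log units; within the scatter), a 2.0-fold lower number from compound 1 to compound 2 (0.30 log units; within the scatter) and a 1.5-fold higher number from compound 2 to compound 3 (0.18 log units; within the scatter), every one within the scatter. Among the compounds with values here, none of these changes branching, so there is no direct read on a tert-butyl group; the chain steps show only that the number hardly moves with the size of this group across the three measured members. On that basis the step is expected to stay within the scatter: a 1.4-fold higher number from compound 3 to compound 4 (0.14 log units; within the scatter). Compound 4 is expected to give 40 nM, with a range from 15 nM to 110 nM.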

Compound 4, half-maximal inhibitory concentration: 168 nM
Compound 4: middle estimate off by 4.2-fold (0.62 log units), on the low side; measured number outside the range, above it.
By their numbers in this assay, from the lowest: compounds 2, 3 and 1 (each within the scatter of the next); then compound 4.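

In this assay, replacing butyl with tert-butyl keeps the same four carbons on this aromatic carbon, para to a large group, yet gives a 5.8-fold higher number from compound 3 to compound 4 (0.76 log units; beyond the scatter), so the arrangement of those carbons matters here in a way that the unbranched chains did not show. Compound 4 also separates from the propyl and heptyl members, with a 4.4-fold higher number from compound 1 to compound 4 (0.65 log units; beyond the scatter) and an 8.8-fold higher number from compound 2 to compound 4 (0.95 log units; beyond the scatter), leaving it apart from all three straight-chain compounds. No data shown account for this shift.

Going by these compounds, it remains open whether a less branched group such as isopropyl or isobutyl on this aromatic carbon would read like the straight chains or like tert-butyl. On these data alone, it is also open how an amine or a carboxylic acid at this place would read in this assay.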